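This account rests on a few compounds, and the source may have more. Where it says the series, first, only, none or still open, it means among the compounds named here.

Measured so far in a functional assay on the whole organism for inhibition, with Mus musculus as the target; on this read-out lower numbers stand for an effect already at smaller amounts and higher numbers for an effect only at larger amounts of compound
Compound 1 `CCCCNC(=O)Nc1cccc2c1CN(C)CC2c1ccc(C)cc1` gives 40 mg/kg
Compound 2 `CCNCC(=O)Nc1cccc2c1CN(C)CC2c1ccccc1` gives 47 mg/kg
Compound 3 `CCNCC(=O)Nc1cccc2c1CN(C)CC2c1ccc(Cl)cc1` gives 24 mg/kg

Compound 3 gives 24 mg/kg in this assay and lies within the usual scatter of both other compounds. Compound 4 `CCNCC(=O)Nc1cccc2c1CN(C)CC2c1ccc(C)cc1` has one change from compound 3, methyl in place of chloro on an aromatic carbon, para to a large group (methyl in place of chloro on an aromatic carbon). The closest measured change is on that same aromatic carbon (a 2.0-fold lower number from compound 2 to compound 3 (0.29 log units; within the scatter)), and it stays within the scatter. Compound 1 carries the 4-methylphenyl group on a different side chain and gives 40 mg/kg in this read-out. No step beyond the scatter is therefore expected in this assay, only a small one (a 1.3-fold higher number from compound 3 to compound 4 (0.10 log units; within the scatter)). For compound 4 the estimated value is 30 mg/kg (expected range 15 mg/kg to 60 mg/kg).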

Compound 4, dose for half-maximal effect: about 45 mg/kg
Compound 4: the middle estimate sits 1.5-fold (0.18 log units) below what was measured; measured number inside the range.
By their numbers in this assay, from the lowest: compounds 3, 1, 4 and 2 (each within the scatter of the next).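

Methyl in place of chloro on this aromatic carbon (a 1.9-fold higher number from compound 3 to compound 4 (0.27 log units; within the scatter)) and methyl in place of hydrogen (a 1.0-fold lower number from compound 2 to compound 4 (0.02 log units; within the scatter)) show that in this assay hydrogen, chloro and methyl at this place cannot be told apart. With the 4-methylphenyl group kept, exchanging the side chain (a 1.1-fold higher number from compound 1 to compound 4 (0.05 log units; within the scatter)) also leaves the two compounds indistinguishable. Nothing measured here offers an explanation for these numbers. From the compounds shown here alone, whether a methoxy group or a carboxylic acid at this place would step beyond the scatter remains open. So does the effect of a longer chain on the carbonyl carbon.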